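Pyrrolidin-1-yl replaces methylamino: an expected flat step

A few compounds are considered here, and "the series" means these few. Any claim that something is new, unique, unknown or untested is made for them only; others in the source may bear on it.

For the measured compounds named here, in a toxicity assay on J774.A1 cells (Mus musculus) for cytotoxicity, read by SYBR Green assay, with a stated time of 1 h (a higher number here means that more compound is needed for the effect, a lower number that less compound is needed), compound 2 `CNc1ccc2cc(-c3cc(Cl)cc(Cl)c3)c(N)nc2c1` gives 3700 nM and stands level with compound 1 `CN(C)c1ccc2cc(-c3cc(Cl)cc(Cl)c3)c(N)nc2c1` at 3700 nM on the numbers so far. Compound 3 `Nc1nc2cc(N3CCCC3)ccc2cc1-c1cc(Cl)cc(Cl)c1` has pyrrolidin-1-yl in place of methylamino on an aromatic carbon and keeps the shared core. Going by the values given here, one measured step bears on this change: hydrogen in place of methyl on a nitrogen on an aromatic ring, no change at the digits printed from compound 1 to compound 2 (within the scatter) within the scatter. That single step is thin evidence for a ring, yet it gives no reason to expect a real shift. In this assay the expected change is a 1.1-fold lower number from compound 2 to compound 3 (0.02 log units; within the scatter) and no larger than the scatter. Compound 3 is estimated at 3500 nM (range 1500 nM to 8000 nM).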

Compound 3, half-maximal effective concentration: 1400 nM
Compound 3: middle estimate off by 2.5-fold (0.40 log units), on the high side; the whole stated range lies above it.
By their numbers in this assay, from the lowest: compound 3; then compounds 1 and 2 (each within the scatter of the next).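

In this assay this aromatic carbon responds to the pyrrolidin-1-yl ring, although losing a methyl from the nitrogen moved nothing: the change gives a 2.6-fold lower number from compound 2 to compound 3 (0.42 log units; beyond the scatter) and likewise a 2.6-fold lower number from compound 1 to compound 3 (0.42 log units; beyond the scatter) on the same carbon. Among the three compounds, only the ring shifts the number, and less compound is needed for the effect. No evidence here accounts for this shift. As far as these compounds go, what remains open is whether piperidin-1-yl, morpholin-4-yl or a plain primary amine on this carbon would follow compound 3 or stay level with compound 2.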